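The source may hold more compounds than are shown below. What is called first, only, known or untested is meant among the compounds shown, and "the series" means these compounds.

Compound 1 `O=[N+]([O-])c1ccc(OCc2cn(C(c3ccccc3)c3ccccc3)nn2)cc1` and compound 2 `Cc1ccc(OCc2cn(C(c3ccccc3)c3ccccc3)nn2)cc1` share one core and differ by methyl in place of nitro on an aromatic carbon. In an assay on isolated protein for inhibition of Aromatase (Homo sapiens), read by fluorescence and colorimetric assay, with a stated time of 30 min (on this read-out higher numbers stand for weaker inhibition and lower numbers for stronger inhibition), compound 1 gives 11600 nM, while compound 2 gives 26800 nM, so that the change gave a 2.3-fold higher number from compound 1 to compound 2 (0.36 log units; beyond the scatter). Compound 3 `N#Cc1ccc(Cn2cc(COc3ccc([N+](=O)[O-])cc3)nn2)cc1` carries a different core; the difference between the two cores is not broken down here. In this assay compound 3 gives 5620 nM, the lowest of the three numbers. Compound 4 `Cc1ccc(OCc2cn(Cc3ccc(C#N)cc3)nn2)cc1` has not yet been measured and differs from compound 3 by methyl in place of nitro on an aromatic carbon, which is the same change, at the same place, as the one made in going from compound 1 to compound 2. Within the data shown here, the step is expected to be a 2.1-fold higher number from compound 3 to compound 4 (0.33 log units; beyond the scatter), resting on the only precedent, because the same change gave a 2.3-fold higher number from compound 1 to compound 2 (0.36 log units; beyond the scatter). Compound 4 is therefore expected to give about 12000 nM.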

Compound 4, half-maximal inhibitory concentration: 4170 nM
Compound 4: middle estimate off by 2.9-fold (0.46 log units), on the high side; measured number below the stated range.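

In this assay, methyl in place of nitro gave a 1.3-fold lower number from compound 3 to compound 4 (0.13 log units; within the scatter), so on this core the two compounds cannot be told apart. The change did not carry over in size from one core to the other: the same change on two cores in this assay, a 2.3-fold higher number (0.36 log units; beyond the scatter) from compound 1 to compound 2 and a 1.3-fold lower number (0.13 log units; within the scatter) from compound 3 to compound 4, 3.1-fold (0.49 log units) apart, beyond the scatter of two such steps. This shows that, for these two pairs, the step depends on the core that carries it, but two pairs do not show which part of the cores matters or what the step would be on a third core.

From the compounds shown here alone, it remains open whether other groups at the same place, such as an amine or a carboxylic acid, would also differ between the two cores. Also open, going by these compounds, is how nitro and methyl would compare on a third core.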